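The source may hold more compounds than are shown below. What is called first, only, known or untested is meant among the compounds shown, and "the series" means these compounds.

Of the compounds shown here, three carry a measured number so far. Compound 1 `Cc1ccc(-c2csc(N/N=C/c3cccs3)n2)cc1` gives 82.8% in a functional assay, read by spectrophotometry, with a stated time of 15 min, tested at 40 ug/mL; on this read-out higher numbers stand for a stronger effect at the one concentration tested and lower numbers for a weaker effect. Compound 2 `COC(=O)c1cc(-c2csc(N/N=C/c3cccs3)n2)ccc1OCc1ccccc1` gives 82.8% in the same read-out. Compound 3 `Fc1ccc(-c2csc(N/N=C/c3ccc(Cl)cc3Cl)n2)cc1` gives 90% in this assay, the highest of the three numbers; the gaps to compound 1 and to compound 2 are both within the usual scatter, so no ordering among the three can be claimed. Going by the values given here, none of the three pairs differs in a single place, so there is no single-point step among the measured compounds from which to read the weight of any one change.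

Compound 4 `Clc1ccc(-c2csc(N/N=C/c3ccc(Cl)cc3Cl)n2)cc1` is not yet measured. It differs from compound 3 in one place: chloro in place of fluoro on an aromatic carbon. A single halogen exchanged for another at one aromatic carbon, with no change in ring count, donors, acceptors or charge, is the kind of change for which, on the numbers seen here, no step beyond the scatter can be foreseen in either direction. The expected step from compound 3 to compound 4 is therefore a number 2 percentage points lower from compound 3 to compound 4 (within the scatter) in this assay. Compound 4 is accordingly estimated at 88% in this assay. The expected lower end for compound 4 is 76% and the upper end is 97%, the range reflecting that the read-out for compound 3 sits near the top of what a single-concentration percentage can show.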

Compound 4, a percentage reported as inhibition, at one concentration (the size of the read-out at that concentration, not a potency): 76.2%
Compound 4: middle estimate off by 11.8 percentage points, on the high side, within the range that was stated.
By their numbers in this assay, from the lowest: compounds 4, 1, 2 and 3 (each within the scatter of the next, the first and the last beyond it).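

The 4-fluorophenyl to 4-chlorophenyl exchange gives the series its first step that can be read at a single place: in this assay, chloro in place of fluoro gives a number 13.8 percentage points lower from compound 3 to compound 4 (beyond the scatter), with the rest of the structure unchanged. The position para to a large group is therefore not indifferent to which of these two halogens it carries, even though the exchange leaves the counts of rings, donors and acceptors and the net charge as they were. This rests on one pair only, so it holds for this exchange on the structure shared by compound 3 and compound 4, and no measurement shown here accounts for the size or direction of the step.

Open, from the compounds shown here alone, is how other groups at this same position, such as bromo, an amine or a carboxylic acid, would stand against fluoro and chloro in this assay. Going by these compounds alone, also open is whether the same exchange gives a step of similar size and direction when the other end of the molecule is that of compound 1 or compound 2, rather than the one shared by compound 3 and compound 4.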